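The source may hold more compounds than are shown below. What is called first, only, known or untested is meant among the compounds shown, and "the series" means these compounds.

Compound 1 `COc1cc(/C=C/C(=O)c2cccc(-n3cc(-c4ccccc4)[nH]c3=O)c2)cc(OC)c1OC`: 950 nM
Compound 2 `COc1ccc(-c2cn(-c3cccc(C(=O)/C=C/c4cc(OC)c(OC)c(OC)c4)c3)c(=O)[nH]2)cc1`: 1850 nM

Among the compounds with values here, in a functional assay on NCI-H522 cells (Homo sapiens) for inhibition (a lower number here means a stronger inhibitor of growth, a higher number a weaker inhibitor of growth), compound 2 gives 1850 nM, the higher of the two numbers measured so far. Compound 1 gives 950 nM, and the gap from compound 1 to compound 2, a 1.9-fold higher number from compound 1 to compound 2 (0.29 log units; within the scatter), is within the scatter, so the two compounds cannot be told apart on these numbers.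

Compound 3 `COc1cc(/C=C/C(=O)c2cccc(-n3cc(-c4cc(OC)c(OC)c(OC)c4)[nH]c3=O)c2)cc(OC)c1OC` has not yet been measured in this assay. It differs from compound 2 in one place: 3,4,5-trimethoxyphenyl in place of 4-methoxyphenyl on an aromatic carbon.

Within the data shown here, only one measured step bears on this change, namely a 1.9-fold higher number from compound 1 to compound 2 (0.29 log units; within the scatter), which introduced a single methoxy group on the same phenyl group and left the number within the scatter. Compound 3 adds two more methoxy groups on that phenyl group. With just one step, and that one within the scatter, no change beyond the scatter is expected for compound 3, a 1.1-fold higher number from compound 2 to compound 3 (0.03 log units; within the scatter). Compound 3 is therefore estimated at 2000 nM, with a range from 700 nM to 6000 nM.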

Compound 3, concentration for 50% growth inhibition: 1050 nM
Beside the measured number, compound 3's estimate is 1.9-fold (0.28 log units) above it, and the stated range covers the measured number.
By their numbers in this assay, from the lowest: compounds 1, 3 and 2 (each within the scatter of the next).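

In this assay putting 3,4,5-trimethoxyphenyl in place of 4-methoxyphenyl gives a 1.8-fold lower number from compound 2 to compound 3 (0.25 log units; within the scatter) and putting it in place of plain phenyl gives a 1.1-fold higher number from compound 1 to compound 3 (0.04 log units; within the scatter) at the same position. Within the data shown here, the position, an aromatic carbon of the five-membered aromatic ring with 2 nitrogen, therefore takes a group of 12 heavy atoms with no step beyond the scatter, which the single methoxy step could not show. Nothing measured here gives a reason for this result.

All three compounds carry only hydrogen or methoxy on this phenyl group, so a phenyl bearing an amine or a carboxylic acid could still shift the number. From the compounds shown here alone, whether any change at this position moves growth inhibition beyond the scatter remains open.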